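Adding One Methyl to Compound 3

This account rests on a few compounds, and the source may have more. Where it says the series, first, only, none or still open, it means among the compounds named here.

Of the compounds shown here, three that differ in one place have been measured in an ADME assay on MDCK-II cells (Canis lupus familiaris) for permeability; a higher number here means that the compound crosses the layer faster, a lower number that the compound crosses the layer more slowly. Compound 1 `CC(C)Oc1cc(Oc2ccc(S(C)(=O)=O)cc2)cc(-c2cccc(=O)[nH]2)c1` gives 18 10^-6 cm/s, compound 2 `CC(C)Oc1cc(Oc2ccc(S(C)(=O)=O)cc2)cc(-c2cncc(=O)[nH]2)c1` gives 94 10^-6 cm/s and compound 3 `CC(C)Oc1cc(Oc2ccc(S(C)(=O)=O)cc2)cc(-c2nccc(=O)[nH]2)c1` gives 24 10^-6 cm/s. Compound 3 stands level with compound 1, as the record shows a 1.3-fold higher number from compound 1 to compound 3 (0.12 log units; within the scatter). Compound 2 stands apart from both, with a 5.2-fold higher number from compound 1 to compound 2 (0.72 log units; beyond the scatter) and a 3.9-fold lower number from compound 2 to compound 3 (0.59 log units; beyond the scatter).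

Compound 4 `Cc1cc(=O)[nH]c(-c2cc(Oc3ccc(S(C)(=O)=O)cc3)cc(OC(C)C)c2)n1` has not yet been measured. It carries one change from compound 3, methyl in place of hydrogen on an aromatic carbon. Among the compounds with values here, no measured step adds a methyl, since all three exchange one six-membered aromatic ring for another, so they offer only a rough guide to size. Such a small addition suggests a slight rise in this assay or no change beyond the scatter. The expected step is a 1.3-fold higher number from compound 3 to compound 4 (0.10 log units; within the scatter). Compound 4 is estimated at 30 10^-6 cm/s, with an expected range from 14 10^-6 cm/s to 65 10^-6 cm/s.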

Compound 4, apparent permeability: 4.8 10^-6 cm/s
Beside the measured number, compound 4's estimate is 6.3-fold (0.80 log units) above it; the whole stated range lies above it.
By their numbers in this assay, from the lowest: compound 4; then compounds 1 and 3 (each within the scatter of the next); then compound 2.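

In this assay, within the data shown here, one methyl on the aromatic carbon next to the ring nitrogen gives a 5.0-fold lower number from compound 3 to compound 4 (0.70 log units; beyond the scatter) for a single added carbon, so this position responds to even the smallest group, which the ring exchanges among the earlier compounds could not show. The same compound also gives a 3.8-fold lower number from compound 1 to compound 4 (0.57 log units; beyond the scatter) and a 20-fold lower number from compound 2 to compound 4 (1.29 log units; beyond the scatter) in the comparisons with the other two rings, and it now has the lowest number of the four. No available measurement gives a reason for this fall.

As far as these compounds go, whether a larger group here, such as ethyl, or a different one, such as an amine, would lower the number further or raise it remains open. Also open, from the compounds shown here alone, is whether a methyl on the rings of compound 1 or compound 2 would produce a similar step.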